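Methylamino in place of hydroxy in compound 1

This account rests on a few compounds, and the source may have more. Where it says the series, first, only, none or still open, it means among the compounds named here.

Measured so far in a functional assay on A549 cells (Homo sapiens) for antiproliferative activity, read by MTT assay, with a stated time of 48 h (on this read-out higher numbers stand for weaker inhibition and lower numbers for stronger inhibition), for two compounds:
compound 1 `C=C(c1cc(OC)c(OC)c(OC)c1)c1ccc(OC)cc1NC(=O)CO` gives 20 nM
compound 2 `C=C(c1ccc(OC)cc1NC(=O)CNC)c1ccc(OC)c2c1OC(C)(C)C=C2` gives 150 nM

Of these two, compound 1 (20 nM) holds the lower number and so the stronger inhibition. Among the compounds with values here, compound 2 (150 nM) is the only other point of comparison, and the gap between the two lies beyond the scatter.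

Next is compound 3 `C=C(c1cc(OC)c(OC)c(OC)c1)c1ccc(OC)cc1NC(=O)CNC`, which keeps the core of compound 1. The change is methylamino in place of hydroxy on a saturated chain carbon bound to a carbonyl carbon.

Within the data shown here, no measured pair isolates this change, so the expectation rests on thin evidence. Compound 2 also bears methylamino and still reads in the nanomolar range (150 nM), on a different core. The two values cannot show how much of the gap belongs to the chain and how much to the core.

A modest expected loss in this assay follows, close to the size of the scatter, and the expected step is a 1.8-fold higher number from compound 1 to compound 3 (0.24 log units; within the scatter) toward a higher number. For compound 3 the estimated value is 35 nM with an expected range from 10 nM to 130 nM in this read-out.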

Compound 3, half-maximal inhibitory concentration: 100 nM
The estimate for compound 3 lay 2.9-fold (0.46 log units) below the measured number; the range from low to high includes it.
By their numbers in this assay, from the lowest: compound 1; then compounds 3 and 2 (each within the scatter of the next).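

In this assay, within the data shown here, this is the first read of the chain exchange on an unchanged core: methylamino in place of hydroxy on a saturated chain carbon bound to a carbonyl carbon gives a 5.0-fold higher number from compound 1 to compound 3 (0.70 log units; beyond the scatter), a modest step that still lies beyond the scatter. The position therefore responds to this exchange even though hydroxy and methylamino are counted with the same number of hydrogen-bond donors and acceptors, while compound 3 at 100 nM and compound 2 at 150 nM, both bearing methylamino on different cores, lie within the scatter of each other. No measurement on hand accounts for the size of this step.

The compounds shown leave open how an unsubstituted amino group, a dimethylamino group, a carboxylic acid or a longer chain would read at this position. They also leave open whether the same exchange on the core of compound 2 would give a step of like size, so the result remains specific to the core of compound 1.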